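The source may report more compounds than this note shows. Statements on the series, on what has been measured and on what is new or still open speak of the compounds shown alone.

Measured so far in a functional assay on U-937 cells (Homo sapiens) for cytotoxicity, read by CCK-8 assay, with a stated time of 72 h; on this read-out lower numbers stand for stronger inhibition and higher numbers for weaker inhibition:

compound 1, `C=CCn1c(=O)/c(=C\c2cccc(C)c2)[nH]c(=O)/c1=C\c1ccccc1OC`, gives 5100 nM.
compound 2, `COc1ccccc1/C=c1\c(=O)[nH]/c(=C/c2cccc(Cl)c2Cl)c(=O)n1C`, gives 100 nM.
compound 3, `C=CCn1c(=O)/c(=C\c2cccc(F)c2)[nH]c(=O)/c1=C\c1ccccc1OC`, gives 2500 nM.

Compound 3 holds the second highest number of the three in this assay. Within the data shown here, its nearest neighbour is compound 1, and the only single-point step in the set runs between these two: a 2.0-fold lower number from compound 1 to compound 3 (0.31 log units; beyond the scatter). Compound 2 sits far below both, but it differs from compound 3 in more than one place, so its number says nothing on its own about any single change.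

Compound 4, `C=CCn1c(=O)/c(=C\c2cc(F)ccc2C)[nH]c(=O)/c1=C\c1ccccc1OC`, differs from compound 3 by methyl in place of hydrogen on an aromatic carbon; read one bond further out, the change is 3-fluorophenyl to 5-fluoro-2-methylphenyl. Among the measured compounds shown here, no measured step puts a methyl onto a ring that already carries a fluoro, and the one step at hand (a 2.0-fold lower number from compound 1 to compound 3 (0.31 log units; beyond the scatter)) exchanges the two groups rather than combining them. It is therefore expected that compound 4 shows a step of about a 1.2-fold higher number from compound 3 to compound 4 (0.08 log units; within the scatter) in this assay, likely within the scatter, direction uncertain. The estimate for compound 4 in this assay is 3000 nM, with a range from 1000 nM to 9000 nM.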

Compound 4, half-maximal inhibitory concentration: 1000 nM
For compound 4 the middle estimate is 3.0-fold (0.48 log units) above the measured one, within the range that was stated.
By their numbers in this assay, from the lowest: compound 2; then compound 4; then compound 3; then compound 1.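

In this assay, methyl on the aromatic carbon ortho to a large group and para to a fluoro group gives a 2.5-fold lower number from compound 3 to compound 4 (0.40 log units; beyond the scatter) on a ring that already carries fluoro, a combination the earlier exchange of the two groups could not show. Read as a change of the whole ring, 5-fluoro-2-methylphenyl in place of 3-methylphenyl gives a 5.1-fold lower number from compound 1 to compound 4 (0.71 log units; beyond the scatter) in the same assay, so among compounds 1, 3 and 4 the ring with both groups has the lowest number. No measurement at hand bears on why these steps occur.

On these data alone, it stays open whether ethyl or an amine on this same carbon would lower the number further. Also open, as far as these compounds go, is whether methyl at this place gives a similar step on a ring without the fluoro group.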